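The source may hold more compounds than are shown below. What is called first, only, known or untested is meant among the compounds shown, and "the series" means these compounds.

Compound 3 `Cc1cc(Oc2cccc(Cl)c2)c(S(C)(=O)=O)cc1C(=O)N=C(N)N` gives 21 nM in a functional assay for inhibition of sodium/hydrogen exchanger (Oryctolagus cuniculus) (on this read-out lower numbers stand for stronger inhibition and higher numbers for weaker inhibition), the second highest of the three numbers recorded; its neighbours are compound 1 `Cc1cc(Cl)c(S(C)(=O)=O)cc1C(=O)N=C(N)N` with 25 nM and compound 2 `Cc1cc(C)c(S(C)(=O)=O)cc1C(=O)N=C(N)N` with 11 nM. The change to compound 4 `Cc1cc(N2CCC(N)CC2)c(S(C)(=O)=O)cc1C(=O)N=C(N)N` is 4-aminopiperidin-1-yl in place of 3-chlorophenoxy on an aromatic carbon. The three measured steps all swap the group at this same aromatic carbon: a 2.3-fold lower number from compound 1 to compound 2 (0.36 log units; beyond the scatter) and the two steps of a 1.2-fold lower number from compound 1 to compound 3 (0.08 log units; within the scatter) and a 1.9-fold higher number from compound 2 to compound 3 (0.28 log units; within the scatter). Chloro, methyl and 3-chlorophenoxy therefore give much the same readout here, but no measured compound carries a non-aromatic ring or a hydrogen-bond donor at this position, so the basis for the estimate is thin. For compound 4 the expected step is a 1.4-fold higher number from compound 3 to compound 4 (0.15 log units; within the scatter), a value estimated near 30 nM with a range from 8 nM to 120 nM.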

Compound 4, half-maximal inhibitory concentration: 9.8 nM
Estimate against measurement, compound 4: 3.1-fold (0.49 log units) above; low and high end bracket the measured number.
By their numbers in this assay, from the lowest: compounds 4, 2, 3 and 1 (each within the scatter of the next, the first and the last beyond it).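

In this assay this aromatic carbon accepts 4-aminopiperidin-1-yl, a non-aromatic ring with a hydrogen-bond donor, with no loss: the swap gives a 2.1-fold lower number from compound 3 to compound 4 (0.33 log units; beyond the scatter) and a 2.6-fold lower number from compound 1 to compound 4 (0.41 log units; beyond the scatter) while a 1.1-fold lower number from compound 2 to compound 4 (0.05 log units; within the scatter) leaves the ring level with methyl. The position therefore holds an amine-bearing ring as well as the small methyl, and the earlier groups gave no sign of this. Open, going by these compounds, is how piperidin-1-yl without the amine, or a carboxylic acid in place of the amine, would read here. Nothing on hand accounts for these steps.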